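Working notes: hydrogen in place of trifluoromethyl

The source may report more compounds than this note shows. Statements on the series, on what has been measured and on what is new or still open speak of the compounds shown alone.

Measured so far:
compound 1 `O=C(Nc1ccc(C(F)(F)F)cc1)C1CCc2ccccc2N1`, 25000 nM
compound 2 `CC(=O)N1c2ccccc2CCC1C(=O)Nc1cc(C(F)(F)F)cc(C(F)(F)F)c1`, > 70000 nM
compound 3 `O=C(Nc1ccccc1C(F)(F)F)C1CCc2ccccc2N1C(=O)c1ccc(Cl)cc1`, 824 nM

In a functional assay on ACHN cells (Homo sapiens) for cytotoxicity, read by sulforhodamine B assay, with a stated time of 72 h (on this read-out higher numbers stand for weaker inhibition of growth and lower numbers for stronger inhibition of growth), compound 1 gives 25000 nM, the highest of the two numbers; the nearest is compound 3 at 824 nM, a gap beyond the scatter. For compound 2 the result is a limit of the assay, > 70000 nM. One of the three values sits at this limit (the limit of > 70000 nM in this assay, at which 1 of the 3 values shown sits). Compound 4 `O=C(Nc1ccccc1)C1CCc2ccccc2N1` is not yet measured in this assay. It differs from compound 1 in one place: hydrogen in place of trifluoromethyl on an aromatic carbon, para to a large group. For the measured compounds named here, no measured pair shows this change, so its size is open; the expectation in this assay is a modest shift towards weaker inhibition, and the expected step is a 1.8-fold higher number from compound 1 to compound 4 (0.26 log units; within the scatter). Compound 4 is expected near 45000 nM, between 15000 nM and 120000 nM.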

Compound 4, concentration for 50% growth inhibition: 72900 nM
Estimate against measurement, compound 4: 1.6-fold (0.21 log units) below; the range from low to high includes it.
By their numbers in this assay, from the lowest: compound 3; then compound 1; then compound 4.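

For the compounds shown here, the first pair for this change gives, in this assay, a 2.9-fold higher number from compound 1 to compound 4 (0.46 log units; beyond the scatter). At this position, trifluoromethyl therefore goes with stronger inhibition of growth than hydrogen, by a modest step. Compound 2 is a limit and not a number, so no step to it can be read: the limit of > 70000 nM in this assay, at which 1 of the 4 values shown sits.

As far as these compounds go, whether an amine or a carboxylic acid on this aromatic carbon would give a lower or a higher number than trifluoromethyl remains open. Also open, from the compounds shown here alone, is whether the step would hold on the rest of compound 3.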